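Thiophen-2-yl for 4-methylphenyl on the sulfonyl sulfur

This account rests on a few compounds, and the source may have more. Where it says the series, first, only, none or still open, it means among the compounds named here.

Two related compounds have been tested so far, compound 1 (`CC(C)C[C@H](NC(=O)CSc1cc(NS(=O)(=O)c2cccs2)c2ccccc2c1O)B(O)O`) and compound 2 (`Cc1ccc(S(=O)(=O)Nc2cc(SC(C)C(=O)N[C@@H](CC(C)C)B(O)O)c(O)c3ccccc23)cc1`). In a functional assay on A549 cells (Homo sapiens) for antiproliferative activity, read by sulforhodamine B assay, with a stated time of 72 h (on this read-out lower numbers stand for stronger inhibition and higher numbers for weaker inhibition), compound 1 gives 7540 nM and compound 2 gives 7280 nM. These two numbers lie within the usual scatter of repeated measurements, so compound 2 stands level with compound 1 and neither can be called the better one.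

The next molecule is compound 3 (`CC(C)C[C@H](NC(=O)C(C)Sc1cc(NS(=O)(=O)c2cccs2)c2ccccc2c1O)B(O)O`), made from compound 2 by a single swap: thiophen-2-yl in place of 4-methylphenyl on a sulfonyl sulfur. The rest of the molecule stays the same.

Within the data shown here, no pair of measured compounds shows this swap on its own, so there is no direct evidence for its effect in this assay. Among the measured compounds shown here, the only guide is the level shared by the two measured compounds, so no clear direction can be argued. The expected change, a 1.0-fold lower number from compound 2 to compound 3 (0.02 log units; within the scatter), is estimated to stay within the scatter. For compound 3 the expected value is 7000 nM, with an estimated range from 3000 nM to 16000 nM.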

Compound 3, half-maximal inhibitory concentration: 11300 nM
For compound 3 the middle estimate is 1.6-fold (0.21 log units) below the measured one; low and high end bracket the measured number.
By their numbers in this assay, from the lowest: compounds 2, 1 and 3 (each within the scatter of the next).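

In this assay, putting thiophen-2-yl in place of 4-methylphenyl on the sulfonyl sulfur gives a 1.6-fold higher number from compound 2 to compound 3 (0.19 log units; within the scatter) and so does not separate the two compounds, even though a six-membered ring of carbon only gives way to a five-membered ring carrying a sulfur. Compound 3 also forms a second one-place pair, with methyl in place of hydrogen on the saturated chain carbon bound to a carbonyl carbon and a sulfur, and this gives a 1.5-fold higher number from compound 1 to compound 3 (0.18 log units; within the scatter) and again no separation. Neither of the first two compounds could show these steps, and together the two steps show that both changes leave the read-out level within repeat-to-repeat variation, though no available measurement offers an explanation for this.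

Whether the group on the sulfonyl sulfur can shift this read-out at all stays open, since the only two groups shown there give level results and a ring such as pyridin-3-yl or a 4-aminophenyl group could behave differently. The chain carbon poses the same question, as only hydrogen and methyl appear there, leaving a longer chain such as ethyl, an amine or a carboxylic acid at that place untested in the compounds shown.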